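A few compounds are considered here, and "the series" means these few. Any claim that something is new, unique, unknown or untested is made for them only; others in the source may bear on it.

Three measured compounds share one core and differ only at the far end of it. Compound 1 `Nc1ccccc1NC(=O)c1ccc(CSC(=S)N2CCc3ccc([N+](=O)[O-])cc32)cc1`, compound 2 `Nc1ccccc1NC(=O)c1ccc(CSC(=S)N2CCCc3ccccc32)cc1` and compound 3 `COc1ccc(N2CCN(C(=S)SCc3ccc(C(=O)Nc4ccccc4N)cc3)CC2)cc1` were each tested in a functional assay on HeLa cells (Homo sapiens) for antiproliferative activity, read by CCK-8 assay, with a stated time of 72 h, tested at 8 uM; a lower number here means a weaker effect, a higher number a stronger effect of the compound at the concentration tested. In this assay compound 1 gives 62.1%, compound 2 gives 35.7% and compound 3 gives 52.3%. Compound 3 therefore stands second highest of the three numbers; its nearest neighbour is compound 1, and the two lie within the scatter of each other, while compound 2 is the furthest from it, by a gap beyond the scatter.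

Compound 4 `N#Cc1ccc(N2CCN(C(=S)SCc3ccc(C(=O)Nc4ccccc4N)cc3)CC2)cc1` has not yet been measured. It differs from compound 3 in a single place: cyano in place of methoxy on an aromatic carbon. Going by the values given here, no measured pair of compounds shows what this exchange of one small group for another does, so nothing here says which way the number should move. The expected step in this assay from compound 3 to compound 4 is therefore a number 2.3 percentage points lower from compound 3 to compound 4 (within the scatter), a change I do not expect to reach beyond the scatter in either direction. On that basis compound 4 is expected to give about 50% in this assay, with a likely range from 30% to 70%.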

Compound 4, a percentage reported as inhibition, at one concentration (the size of the read-out at that concentration, not a potency): 70.6%
Compound 4: middle estimate off by 20.6 percentage points, on the low side; measured number above the stated range.
By their numbers in this assay, from the lowest: compound 2; then compounds 3, 1 and 4 (each within the scatter of the next, the first and the last beyond it).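

Going by these compounds alone, replacing methoxy with cyano on an aromatic carbon para to a large group gives a number 18.3 percentage points higher from compound 3 to compound 4 (beyond the scatter) in this assay, the first step here between two measured compounds that differ in one place, and it shows that the number responds to the group at this position. The change is also a close one by the simple counts: methoxy and cyano each have 2 heavy atoms and 1 hydrogen-bond acceptor, with no hydrogen-bond donor, ring or net charge, so these counts do not separate the two groups even though the step lies beyond the scatter. Nothing available here measures what underlies this step.

With a single exchange at this position, the compounds shown leave open whether the step reflects something general or is particular to cyano, and an amine, a carboxylic acid or a chlorine atom on the same carbon would help to tell these apart. Because the read-out is taken at one concentration, they also leave open how compound 3 and compound 4 compare in potency.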